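The source may report more compounds than this note shows. Statements on the series, on what has been measured and on what is new or still open speak of the compounds shown alone.

Measured so far, in an in vivo functional assay on the whole organism for inhibition of 3-hydroxy-3-methylglutaryl-coenzyme A reductase (Rattus norvegicus), at a dose of 0.2 mg/kg by the oral route; a lower number here means a weaker effect, a higher number a stronger effect of the compound at the dose given:
- compound 1, `CC(C)c1nc2cc(-c3ccccc3)nn2c(-c2ccc(F)cc2)c1/C=C/[C@@H](O)C[C@@H](O)CC(=O)O`, gives -1.4%
- compound 2, `Cc1cc2nc(C3CC3)c(/C=C/[C@@H](O)C[C@@H](O)CC(=O)O)c(-c3ccc(F)cc3)n2n1`, gives -27.1%

Of these two, compound 2 stands lowest; compound 1 lies higher by a gap beyond the usual scatter of this assay. The two compounds differ in more than one place, so their values show only that gap, not what any single change does.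

The next compound, compound 3, `Cc1cc2nc(C(C)C)c(/C=C/[C@@H](O)C[C@@H](O)CC(=O)O)c(-c3ccc(F)cc3)n2n1`, has not yet been measured in this assay. It follows from compound 2 by one change: isopropyl in place of cyclopropyl on an aromatic carbon. Within the data shown here, no measured pair shows this change on its own, so there is nothing here to say how large a step it brings. Two groups of equal size swap, one a ring and one a chain. The expected step is small, from compound 2 to compound 3 of a number 17.1 percentage points higher from compound 2 to compound 3 (beyond the scatter), not clearly beyond the scatter. For compound 3 the estimate in this assay is -10%, with a range from -35% to 15%.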

Compound 3, a percentage reported as inhibition, in the whole organism at one dose (the size of the read-out at that dose, not a potency): -6.1%
Compound 3: middle estimate off by 3.9 percentage points, on the low side; the range from low to high includes it.
By their numbers in this assay, from the lowest: compound 2; then compounds 3 and 1 (each within the scatter of the next).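

On the aromatic carbon next to the ring nitrogen, a ring and a chain of the same carbon count are not interchangeable in this assay: isopropyl in place of cyclopropyl gives a number 21 percentage points higher from compound 2 to compound 3 (beyond the scatter) and counts as a modest step. At the other changed position, methyl in place of phenyl on an aromatic carbon gives a number 4.7 percentage points lower from compound 1 to compound 3 (within the scatter) and so shows no clear difference between these two groups when isopropyl is present. Nothing available explains either result.

On these data alone, it remains open whether the cyclopropyl to isopropyl step would look the same with phenyl in place of methyl. Also open, as far as these compounds go, is how an ethyl or tert-butyl group would compare with isopropyl on the same carbon, and how an amine would compare with methyl.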